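Working notes: amide aryl swap in the quinazoline-free series

The source may report more compounds than this note shows. Statements on the series, on what has been measured and on what is new or still open speak of the compounds shown alone.

Measured so far:
compound 1 `O=C(CSc1nc(Nc2ccccc2)c2ccccc2n1)Nc1cccc([N+](=O)[O-])c1` — 33000 nM
compound 2 `O=C(CSc1nc(Nc2ccccc2)c2ccccc2n1)Nc1ccc(F)cc1` — 34100 nM

In a functional assay on MDA-MB-231 cells (Homo sapiens) for inhibition, read by MTT assay, with a stated time of 72 h (on this read-out higher numbers stand for weaker inhibition and lower numbers for stronger inhibition), compound 2 and compound 1 sit together; the step of a 1.0-fold higher number from compound 1 to compound 2 (0.01 log units; within the scatter) lies within the scatter, so neither number separates from the other. Compound 3 `O=C(CSc1nc(Nc2ccccc2)c2ccccc2n1)Nc1ccc(Cl)c(Cl)c1` differs from compound 2 by 3,4-dichlorophenyl in place of 4-fluorophenyl on an amide-type nitrogen. Among the compounds with values here, the only measured step that bears on this change is a 1.0-fold higher number from compound 1 to compound 2 (0.01 log units; within the scatter), an exchange of the aryl group on the same amide-type nitrogen that left the number unchanged. On that basis no step beyond the scatter is expected for compound 3 in this assay: the expected value is 30000 nM, in a range from 12000 nM to 75000 nM. The step this estimate implies is a 1.1-fold lower number from compound 2 to compound 3 (0.06 log units; within the scatter).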

Compound 3, half-maximal inhibitory concentration: 14500 nM
Estimate against measurement, compound 3: 2.1-fold (0.32 log units) above; low and high end bracket the measured number.
By their numbers in this assay, from the lowest: compound 3; then compounds 1 and 2 (each within the scatter of the next).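

At this amide-type nitrogen, the aryl group can shift the number in this assay: 3,4-dichlorophenyl brings a 2.4-fold lower number from compound 2 to compound 3 (0.37 log units; beyond the scatter) and a 2.3-fold lower number from compound 1 to compound 3 (0.36 log units; beyond the scatter), whereas exchanging 3-nitrophenyl for 4-fluorophenyl gave a step within the scatter. Both new steps are modest, so this position responds, but only slightly among the three compounds. Nothing available explains the shift.

From the compounds shown here alone, it remains open whether a phenyl ring carrying a single chlorine, an unsubstituted phenyl, or a phenyl bearing an amine or a carboxylic acid would give a comparable step. Going by these compounds, whether the step carries over to changes on the shared core is also open.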